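Trading the Nitrile Ring for a Chloro-Methyl Ring

The source may report more compounds than this note shows. Statements on the series, on what has been measured and on what is new or still open speak of the compounds shown alone.

Compound 1, `CC/C(=C(/c1ccc(/C=C/C(=O)O)cc1)c1cc2ccccc2[nH]1)c1ccccc1C#N`: 9 nM
Compound 2, `CC/C(=C(/c1ccc(/C=C/C(=O)O)cc1)c1cc2ccccc2[nH]1)c1cccc(OC(F)(F)F)c1`: 282 nM
Compound 3, `CC/C(=C(/c1ccc(/C=C/C(=O)O)cc1)c1cc2ccccc2[nH]1)c1cccc(F)c1C#N`: 40 nM

Of the compounds shown here, three sharing one core have been measured in a functional assay on MCF7 cells (Homo sapiens) for inhibition; on this read-out higher numbers stand for weaker inhibition and lower numbers for stronger inhibition. Among them compound 3 holds the second highest number: compound 1 sits lower, by the step of a 4.4-fold higher number from compound 1 to compound 3 (0.65 log units; beyond the scatter), while compound 2 sits higher, by the step of a 7.1-fold lower number from compound 2 to compound 3 (0.85 log units; beyond the scatter) read in reverse.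

Compound 4, `CC/C(=C(/c1ccc(/C=C/C(=O)O)cc1)c1cc2ccccc2[nH]1)c1ccc(Cl)c(C)c1`, has not yet been measured. Its difference from compound 3 is 4-chloro-3-methylphenyl in place of 2-cyano-3-fluorophenyl on a double-bonded chain carbon bound to a double-bonded chain carbon and a saturated chain carbon.

Within the data shown here, two measured steps bear on this. The step of a 31-fold higher number from compound 1 to compound 2 (1.50 log units; beyond the scatter) shows what happened when a ring carrying a nitrile was exchanged for one without it, and the step of a 7.1-fold lower number from compound 2 to compound 3 (0.85 log units; beyond the scatter) shows the reverse exchange. Both point the same way: the rings without the nitrile gave the higher numbers. Compound 4 again lacks the nitrile, carrying chloro and methyl instead, so a rise in number, modest to large, is expected in this assay.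

For compound 4 the expected value in this assay is 200 nM, with a range from 50 nM to 800 nM. This corresponds to an expected step of a 5.0-fold higher number from compound 3 to compound 4 (0.70 log units; beyond the scatter).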

Compound 4, half-maximal inhibitory concentration: 840 nM
Estimate against measurement, compound 4: 4.2-fold (0.62 log units) below, and the stated range ends below it.
By their numbers in this assay, from the lowest: compound 1; then compound 3; then compound 2; then compound 4.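

Exchanging the 2-cyano-3-fluorophenyl ring for 4-chloro-3-methylphenyl on this double-bonded chain carbon gives the largest rise yet seen from compound 3 in this assay (a 21-fold higher number from compound 3 to compound 4 (1.32 log units; beyond the scatter)), and the gap from the best compound shown is wider still (a 93-fold higher number from compound 1 to compound 4 (1.97 log units; beyond the scatter)). Until now only one ring without a nitrile had been seen here, whereas two such rings now both sit above the two nitrile-bearing rings, and no compound among these four goes against that pattern. The two rings without a nitrile are also not equal to each other (a 3.0-fold higher number from compound 2 to compound 4 (0.47 log units; beyond the scatter)), so this position responds to more than the loss of the nitrile alone, though nothing given here explains why these rings differ.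

Chloro and methyl enter together, so their separate contributions stay unknown, and a ring carrying only one of them would be needed to tell them apart. On these data alone, it also remains open whether another group, such as an amine or a methoxy group, could stand in place of the nitrile and keep the number as low as in compound 1.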